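This account rests on a few compounds, and the source may have more. Where it says the series, first, only, none or still open, it means among the compounds named here.

Going by the values given here, compound 2 `COc1cc(-c2cc(-c3cccs3)nc(-c3ccccc3)n2)cc(OC)c1OC` gives 17000 nM in a functional assay on HCT-116 cells (Homo sapiens) for inhibition, read by MTT assay, with a stated time of 48 h (a higher number here means a weaker inhibitor, a lower number a stronger inhibitor), the highest of the two numbers measured so far; its nearest neighbour is compound 1 `COc1cc(-c2cc(-c3ccc(N)cc3)nc(-c3ccccc3)n2)cc(OC)c1OC`, which in this assay gives 12300 nM, and the step of a 1.4-fold higher number from compound 1 to compound 2 (0.14 log units; within the scatter) lies within the scatter. That single step, in which thiophen-2-yl replaced 4-aminophenyl on an aromatic carbon, is the only measured one that bears on the move to compound 3 `COc1cc(-c2cc(-c3ccc(O)cc3)nc(-c3ccccc3)n2)cc(OC)c1OC`. The change is 4-hydroxyphenyl in place of thiophen-2-yl on an aromatic carbon. The incoming 4-hydroxyphenyl resembles the 4-aminophenyl of compound 1 in being a six-membered aromatic ring of carbon only, and the measured step between that kind of group and thiophen-2-yl was small. Compound 3 is therefore expected to land close to compound 2 in this assay, with an expected step of a 1.4-fold lower number from compound 2 to compound 3 (0.15 log units; within the scatter) that does not reach beyond the scatter. Among the compounds with values here, no measured pair shows a hydroxyl directly, so the expectation rests on compound 1 alone. The estimate for compound 3 in this assay is 12000 nM, within a range from 5500 nM to 26000 nM.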

Compound 3, half-maximal inhibitory concentration: 11900 nM
Beside the measured number, compound 3's estimate is 1.0-fold (0.00 log units) above it, and the stated range covers the measured number.
By their numbers in this assay, from the lowest: compounds 3, 1 and 2 (each within the scatter of the next).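

In this assay, going by these compounds alone, the exchange of thiophen-2-yl for 4-hydroxyphenyl on this aromatic carbon gives a 1.4-fold lower number from compound 2 to compound 3 (0.15 log units; within the scatter), so the first compound with a hydroxyl at this site stands level with the one bearing the five-membered sulfur ring, even though the entering group carries a hydrogen-bond donor and the leaving group carries none. Within the data shown here, the new pair also gives the first direct comparison of two substituents on the same phenyl ring at this position, and hydroxy in place of amino yields a 1.0-fold lower number from compound 1 to compound 3 (0.01 log units; within the scatter), so these two groups cannot be told apart here. All three groups at this site now lie within the scatter of one another, and nothing available explains why the steps are this small.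

The compounds shown leave open whether any group at this position can move the number beyond the scatter, for instance a carboxylic acid or a longer chain such as a butoxy group on the phenyl ring in place of the hydroxyl. They also leave open whether the phenyl group at the other ring carbon, constant across all three compounds, matters more than this site does.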